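Methyl removal on the furan ring: compound 1 to compound 4

A few compounds are considered here, and "the series" means these few. Any claim that something is new, unique, unknown or untested is made for them only; others in the source may bear on it.

Compound 1 `COc1cccc(Nc2nccc(-c3ccc(C)o3)n2)c1`: 1500 nM
Compound 2 `c1csc(-c2ccnc(Nc3ccc(-n4ccnc4)cc3)n2)c1`: 4300 nM
Compound 3 `CC(=O)N(C)c1ccc(Nc2nccc(-c3ccccn3)n2)cc1`: 1800 nM

All three were read in a functional assay for inhibition, with Homo sapiens as the target; on this read-out lower numbers stand for stronger inhibition and higher numbers for weaker inhibition. Compound 1 gives the lowest of the three numbers; compound 3 stands within the scatter of compound 1, while compound 2 lies beyond it with the higher number. Compound 4 `COc1cccc(Nc2nccc(-c3ccco3)n2)c1` is not yet measured. It differs from compound 1 in one place: hydrogen in place of methyl on an aromatic carbon. No measured pair in this set carries the same change, so its size is not shown by the data. A change of this kind, a single small group taken off the furan, is expected to move this assay little: no step beyond the scatter, or at most a slight rise. The step from compound 1 to compound 4 is therefore expected as a 1.5-fold higher number from compound 1 to compound 4 (0.17 log units; within the scatter). Compound 4 is estimated at 2200 nM, between 900 nM and 5500 nM.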

Compound 4, half-maximal inhibitory concentration: 400 nM
Compound 4: the middle estimate sits 5.5-fold (0.74 log units) above what was measured; measured number below the stated range.
By their numbers in this assay, from the lowest: compound 4; then compounds 1 and 3 (each within the scatter of the next); then compound 2.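

In this assay, going from 5-methylfuran-2-yl to furan-2-yl gives a 3.8-fold lower number from compound 1 to compound 4 (0.57 log units; beyond the scatter) and so is a step beyond the scatter. The position next to the ring oxygen is therefore sensitive to this single change, with hydrogen giving the lower number than methyl. Nothing measured here accounts for this step.

From the compounds shown here alone, whether any group at this position raises the number remains open: chlorine, an amine or a longer chain such as ethyl could separate these possibilities. Going by these compounds, whether the same change gives a similar step with other groups on the shared core also remains open.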